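The source may hold more compounds than are shown below. What is called first, only, known or untested is meant among the compounds shown, and "the series" means these compounds.

In a functional assay on MDA-MB-468 cells (Homo sapiens) for antiproliferative activity, read by MTT assay, with a stated time of 72 h (on this read-out higher numbers stand for weaker inhibition and lower numbers for stronger inhibition), compound 1 (`COc1cc(-c2nccn2CC(C)C)cc(OC)c1OC`) gives > 100000 nM, and this is a limit of the assay, not a number. Compound 3 (`COc1cc(-c2nccn2-c2cccc(C)c2)cc(OC)c1OC`) gives 22600 nM. Compound 2 (`COc1ccc(-n2ccnc2-c2cc(OC)c(OC)c(OC)c2)cc1[N+](=O)[O-]`) gives 100 nM. Of the two values that are true numbers, compound 3 therefore holds the higher, which means the weaker inhibition.

The next compound, compound 4 (`COc1cc(-c2nccn2-c2cccc([N+](=O)[O-])c2)cc(OC)c1OC`), has nitro in place of methyl on an aromatic carbon, meta to a large group: nitro in place of methyl on an aromatic carbon.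

Going by the values given here, only one measured step lies nearby. It is an at least 4.4-fold lower number from compound 1 to compound 3 (0.64 log units; beyond the scatter), and it comes with 3-methylphenyl in place of isobutyl on an aromatic nitrogen. That step bears only indirectly on the new change, since it does not replace the methyl itself. Compound 2 also carries a nitro and gives 100 nM, which offers some reason to expect a lower number, although no measured step isolates that group. A move towards stronger inhibition is therefore expected in this assay, probably without reaching the value of compound 2. The expected size is a 7.5-fold lower number from compound 3 to compound 4 (0.88 log units; beyond the scatter). For compound 4 the estimated value is 3000 nM, with an expected range from 600 nM to 15000 nM.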

Compound 4, half-maximal inhibitory concentration: 7200 nM
Estimate against measurement, compound 4: 2.4-fold (0.38 log units) below; the range from low to high includes it.
By their numbers in this assay, from the lowest: compound 2; then compound 4; then compound 3. At a limit, above all of these: compound 1.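

In this assay, the carbon meta to a large group on the six-membered aromatic ring responds to what is placed on it: nitro in place of methyl brings a 3.1-fold lower number from compound 3 to compound 4 (0.50 log units; beyond the scatter) and so this change counts as a modest gain in inhibition. Nitro alone, however, does not bring a compound close to compound 2, as hydrogen in place of methoxy on an aromatic carbon brings a 72-fold higher number from compound 2 to compound 4 (1.86 log units; beyond the scatter) and this large step runs towards weaker inhibition. Since compound 2 and compound 4 both carry nitro, the methoxy of compound 2 weighs far more in this comparison than the exchange of methyl for nitro does in the step to compound 4.

On these data alone, whether nitro itself is the best choice on this carbon stays open, since an amine, a nitrile or a carboxylic acid in the same place could give quite different numbers, and one exchange cannot show which of these groups would do better. Nothing measured here bears on the size of either step.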